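A few compounds are considered here, and "the series" means these few. Any claim that something is new, unique, unknown or untested is made for them only; others in the source may bear on it.

Of the compounds shown here, two built on a shared core have been tested in a functional assay on A549 cells (Homo sapiens) for cytotoxicity, read by MTT assay, with a stated time of 72 h; on this read-out lower numbers stand for stronger inhibition and higher numbers for weaker inhibition. Compound 1 `COc1cccc(/C=C2\CCC/C(=C\c3cc(OC)c(OC)c(OC)c3)C2=O)c1OC` gives a real number there, 5900 nM. Compound 2 `COc1ccc(/C=C2\CCC/C(=C\c3ccccc3Cl)C2=O)cc1OC` gives > 20000 nM, and this is a limit of the assay and not a number. Compound 2 therefore stands at the weak end of what has been measured: the limit of > 20000 nM in this assay, at which 1 of the 2 values shown sits.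

Compound 3 `COc1ccc(/C=C2\CCC/C(=C\c3ccc(Br)cc3)C2=O)cc1OC` differs from compound 2 in one place, with 4-bromophenyl in place of 2-chlorophenyl on a double-bonded chain carbon bound to a double-bonded ring carbon. Within the data shown here, no measured pair of compounds shows what a swap of this kind does, so any expectation here is loose. Compound 1, at 5900 nM, shows that the shared core can reach a measurable value in this assay, which leaves room for movement toward stronger inhibition. Even so, a small shift is the most that is expected, and it may not rise clearly beyond the usual scatter. The expected change is an at least 1.2-fold lower number from compound 2 to compound 3 (0.09 log units; that floor lies within the scatter). For compound 3 the estimated value is 16000 nM, with an expected range from 5000 nM to 35000 nM.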

Compound 3, half-maximal inhibitory concentration: 16000 nM
Compound 3: middle estimate and measured number agree at the digits printed, within the range that was stated.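

Compound 2 gives only a limit of the assay in this assay, > 20000 nM, so it put no real number on this position, on a double-bonded chain carbon bound to a double-bonded ring carbon. Among these compounds, with 4-bromophenyl in place of 2-chlorophenyl there, the result is an at least 1.2-fold lower number from compound 2 to compound 3 (0.09 log units; that floor lies within the scatter), and compound 3 is the first compound with this change to give a real number, which shows that a halogen-bearing phenyl group at this position can sit within the measurable range of the assay. The true size of the step remains unknown, and it cannot be called a clear gain, because one end of it is a limit: the limit of > 20000 nM in this assay, at which 1 of the 3 values shown sits.

This swap changes two things at once, chlorine to bromine and the 2- to the 4- in the group's name, and 4-chlorophenyl at this position would tell those two changes apart. Also open, going by these compounds, is how a group without any halogen, such as 4-aminophenyl or a phenyl ring carrying a carboxylic acid, would read out at this same position.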